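The source may report more compounds than this note shows. Statements on the series, on what has been measured and on what is new or still open speak of the compounds shown alone.

Of the compounds shown here, three have been tested in a functional assay on the whole organism (strain Wistar Albino) for inhibition, with Rattus norvegicus as the target, read by paw edema, with a stated time of 1 h, at a dose of 20 mg/kg; a lower number here means less inhibition, a higher number more inhibition at the dose given (going by the name of the read-out). Compound 1 `Cc1cc(-c2nn3c(-c4ccoc4C)nnc3s2)c2ccccc2n1` gives 7.23%. Compound 2 `COc1ccc(Cl)c(-c2nnc3sc(-c4ccnc(Cl)c4)nn23)c1` gives 14.4%, and compound 3 `COc1ccc(Cc2nnc3sc(-c4ccnc(Cl)c4)nn23)cc1OC` gives 11.2%. Compound 2 thus stands with its number a few points apart from compound 3 and somewhat further from compound 1, yet both of these gaps lie within the usual scatter of repeated measurements, so the three numbers cannot be told apart on this evidence. No pair of these compounds differs in only one place, so no single structural step has yet been tied to a change in this assay.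

Compound 4 `COc1ccc(Cl)c(-c2nnc3sc(-c4ccnc(F)c4)nn23)c1` has not yet been measured. It differs from compound 2 by one change: fluoro in place of chloro on an aromatic carbon. Among the measured compounds shown here, because compound 2 gives 14.4% and nothing among the measured compounds points to a larger effect of so small a change, the step from compound 2 to compound 4 is expected to be a number 1.4 percentage points lower from compound 2 to compound 4 (within the scatter), that is, none beyond the scatter. Compound 4 is therefore estimated to give 13%, within a range from 4% to 25%.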

Compound 4, a percentage reported as inhibition, in the whole organism at one dose (the size of the read-out at that dose, not a potency): 18.5%
Beside the measured number, compound 4's estimate is 5.5 percentage points below it; the measured number falls inside the stated range.
By their numbers in this assay, from the lowest: compounds 1, 3, 2 and 4 (each within the scatter of the next, the first and the last beyond it).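

Among the compounds shown here, this is the first step that changes one place only, so this assay can now be read against a single structural difference. On the 2-chloropyridin-4-yl group, at the carbon next to the ring nitrogen, fluoro in place of chloro gives a number 4.1 percentage points higher from compound 2 to compound 4 (within the scatter), so this exchange leaves no change that can be told from the scatter. Nothing at hand explains this step or says what either group does at this position.

On these data alone, whether an amine or a carboxylic acid on this same carbon would move the number beyond the scatter remains open. Also open, as far as these compounds go, is whether the same exchange at the chloro on the methoxy-bearing ring would read alike, and whether this step would hold at another dose or time.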